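A few compounds are considered here, and "the series" means these few. Any claim that something is new, unique, unknown or untested is made for them only; others in the source may bear on it.

Going by the values given here, compound 3 `CNC(=O)[C@@]12C[C@@H]1[C@@H](n1cnc3c(NC)nc(C#Cc4ccc(CO)cc4)nc31)[C@H](O)[C@@H]2O` gives 16% in an assay on CHO cells for displacement of a labelled ligand from adenosine receptor A1 (Homo sapiens), read by scintillation counting, with a stated time of 60 min, tested at 10 uM (a lower number here means less inhibition, a higher number more inhibition at the concentration tested (going by the name of the read-out)), the second highest of the three numbers measured so far. Compound 1 `CNC(=O)[C@@]12C[C@@H]1[C@@H](n1cnc3c(NC)nc(C#Cc4ccccc4F)nc31)[C@H](O)[C@@H]2O` gives 20%, and the step of a number 4 percentage points lower from compound 1 to compound 3 (within the scatter) lies within the scatter; compound 2 `CNC(=O)[C@@]12C[C@@H]1[C@@H](n1cnc3c(NC)nc(C#Cc4ccccc4OC)nc31)[C@H](O)[C@@H]2O` gives 12%, and the step of a number 4 percentage points higher from compound 2 to compound 3 (within the scatter) likewise stays within the scatter. Compound 4 `CNC(=O)[C@@]12C[C@@H]1[C@@H](n1cnc3c(NC)nc(C#Cc4ccsc4)nc31)[C@H](O)[C@@H]2O` differs from compound 3 by thiophen-3-yl in place of 4-(hydroxymethyl)phenyl on a triple-bonded carbon. The two measured steps that swap the group on the triple-bonded carbon, a number 4 percentage points lower from compound 1 to compound 3 (within the scatter) and a number 4 percentage points higher from compound 2 to compound 3 (within the scatter), are both small, so a further swap at the same place is expected to move the number in this assay by no more than the scatter, with a number 1 percentage points lower from compound 3 to compound 4 (within the scatter) as the estimated step. For compound 4 the expected value is 15%, ranging from 5% to 26%.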

Compound 4, a percentage reported as inhibition, at one concentration (the size of the read-out at that concentration, not a potency): 11%
The estimate for compound 4 lay 4 percentage points above the measured number; low and high end bracket the measured number.
By their numbers in this assay, from the lowest: compounds 4, 2, 3 and 1 (each within the scatter of the next).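

With thiophen-3-yl on the triple-bonded carbon, this assay gives a number 5 percentage points lower from compound 3 to compound 4 (within the scatter) and a number 1 percentage points lower from compound 2 to compound 4 (within the scatter) and a number 9 percentage points lower from compound 1 to compound 4 (within the scatter) as its steps. A five-membered aromatic ring with a sulfur atom therefore reads like the six-membered rings here, and losing the hydrogen-bond donor of 4-(hydroxymethyl)phenyl changes nothing beyond the scatter. No available evidence explains this result. Still open, going by these compounds, is whether any group at this place moves the number beyond the scatter, such as a ring carrying an amine or a carboxylic acid, or a longer chain with no ring.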